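Huh-7 cytotoxicity notes, compound 3 to compound 4

The source may report more compounds than this note shows. Statements on the series, on what has been measured and on what is new or still open speak of the compounds shown alone.

Three members of the series have been tested in a functional assay on Huh-7 cells (Homo sapiens) for cytotoxicity, read by MTT assay, with a stated time of 3 days; on this read-out higher numbers stand for lower toxicity in this test and lower numbers for higher toxicity in this test. Compound 1 `CSCc1ncnc2c1ncn2[C@@H]1O[C@H](CO)[C@@H](O)[C@H]1O` carries methylsulfanyl on the saturated chain carbon bound to an aromatic carbon. In this assay compound 1 gives > 100000 nM, which is a limit of the assay and not a number. Compound 2 `OC[C@H]1O[C@@H](n2cnc3c(Cn4cccn4)ncnc32)[C@H](O)[C@@H]1O` carries 1H-pyrazol-1-yl on that saturated chain carbon. In this assay compound 2 gives > 250000 nM, again a limit. Compound 3 `OCCSCc1ncnc2c1ncn2[C@@H]1O[C@H](CO)[C@@H](O)[C@H]1O` carries (2-hydroxyethyl)sulfanyl on that saturated chain carbon. In this assay compound 3 gives > 100000 nM, also a limit. Compound 3 thus stands at the limit of > 100000 nM in this assay, at which 2 of the 3 values shown sit, while compound 2 sits at the limit of > 250000 nM in this assay, at which 1 of the 3 values shown sits. None of the three measured steps can be read: a step that the two limits leave unreadable from compound 1 to compound 2, a step that the two limits leave unreadable from compound 1 to compound 3 and a step that the two limits leave unreadable from compound 2 to compound 3.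

Compound 4 `O=c1ccccn1Cc1ncnc2c1ncn2[C@@H]1O[C@H](CO)[C@@H](O)[C@H]1O` is not yet measured. It differs from compound 3 as follows: a group of 7 heavy atoms (5 carbon, 1 nitrogen, 1 oxygen; one six-membered aromatic ring with 1 hetero atom) in place of a group of 4 heavy atoms (2 carbon, 1 oxygen, 1 sulfur; no ring), on a saturated chain carbon bound to an aromatic carbon. Going by the values given here, the steps that bear on this change are the two exchanges on the same saturated chain carbon bound to an aromatic carbon, a step that the two limits leave unreadable from compound 1 to compound 2 and a step that the two limits leave unreadable from compound 2 to compound 3, and both leave their size unreadable; every value so far is a limit. For compound 4 the expected step is a step that the limit leaves unreadable from compound 3 to compound 4, that is, nothing beyond the scatter. Compound 4 is estimated at 150000 nM, within 50000 nM to 500000 nM, most likely reported again as a limit.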

Compound 4, half-maximal cytotoxic concentration: > 100000 nM
Compound 4 gave a limit, no number (the forecaster's own chance of this, stated with the estimate: 85%); the middle value is on the limit's open side.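

In this assay compound 4 gives > 100000 nM, a limit of the assay and not a number. The steps joining compound 4 to compound 1, compound 2 and compound 3 therefore cannot be read. The compounds shown leave open where any actual half-maximal cytotoxic concentration lies, and whether the group on the saturated chain carbon bound to an aromatic carbon affects it.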